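Bromophenyl for Nitrophenyl: What Compound 4 Might Show

This account rests on a few compounds, and the source may have more. Where it says the series, first, only, none or still open, it means among the compounds named here.

Compound 1 `N#Cc1c(-c2ccc(F)cc2)c(C#N)c(=O)n(/N=C/c2cn(-c3ccccc3)nc2-c2ccccc2)c1N` in an ADME assay on HeLa cells (Homo sapiens) for cytotoxicity, read by MTT assay (on this read-out lower numbers stand for stronger inhibition and higher numbers for weaker inhibition), gives > 200 ug/mL, a limit of the assay.
Compound 2 `Cc1ccc(-c2c(C#N)c(N)n(/N=C/c3cn(-c4ccccc4)nc3-c3ccccc3)c(=O)c2C#N)cc1` gives > 200 ug/mL, again a limit.
Compound 3 `N#Cc1c(-c2cccc([N+](=O)[O-])c2)c(C#N)c(=O)n(/N=C/c2cn(-c3ccccc3)nc2-c2ccccc2)c1N` gives > 200 ug/mL, also a limit.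

Compound 3 therefore stands where every measured member of this series stands: at a limit rather than at a number. Within the limit of > 200 ug/mL in this assay, at which 3 of the 3 values shown sit, no compound separates itself from the others, and the three steps that connect them, a step that the two limits leave unreadable from compound 1 to compound 2, a step that the two limits leave unreadable from compound 1 to compound 3 and a step that the two limits leave unreadable from compound 2 to compound 3, are not readable in size.

Compound 4 `N#Cc1c(-c2ccccc2Br)c(C#N)c(=O)n(/N=C/c2cn(-c3ccccc3)nc2-c2ccccc2)c1N` differs from compound 3 in one place: 2-bromophenyl in place of 3-nitrophenyl on an aromatic carbon. The three measured steps all swap one aryl group on that same aromatic carbon, and none of them produced a readable step in this assay, so they give no guidance on the direction of the present exchange either.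

Compound 4 is accordingly expected to behave like its neighbours, with the step that the limit leaves unreadable from compound 3 to compound 4 not readable within the scatter. The estimate for compound 4 in this assay is 250 ug/mL, with a range from 120 ug/mL to 500 ug/mL, and it is most likely that the assay will again report only a limit.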

Compound 4, half-maximal inhibitory concentration: > 200 ug/mL
Compound 4: only a limit was reported (the forecaster's own chance of this, stated with the estimate: 85%); the middle value is on the limit's open side.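

No step linking compound 4 to compound 1, compound 2 or compound 3 can be read in this assay, because all four compounds sit at the same limit: the limit of > 200 ug/mL in this assay, at which 4 of the 4 values shown sit.

The compounds shown leave open whether 4-fluorophenyl, 4-methylphenyl, 3-nitrophenyl and 2-bromophenyl on the shared core differ at all in this assay.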